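The source may report more compounds than this note shows. Statements on the series, on what has been measured and on what is new or still open speak of the compounds shown alone.

Compound 1 `CC(C)c1ccc(NC(=O)[C@H]2CN(C)C[C@@H]2c2ccc(/C=C/C(=O)Nc3ccccc3N)cc2)cc1`: 10 mL/min/kg
Compound 2 `CN1C[C@H](C(=O)Nc2ccccc2F)[C@@H](c2ccc(/C=C/C(=O)Nc3ccccc3N)cc2)C1`: 10 mL/min/kg

In an in vitro ADME assay on microsomes from liver (Homo sapiens) for pharmacokinetics, read by LC-MS, with a stated time of 10 min, tested at 1 uM (on this read-out lower numbers stand for slow clearance and higher numbers for fast clearance), compound 2 stands level with compound 1 at the digits shown. For the measured compounds named here, the one measured step, no change at the digits printed from compound 1 to compound 2 (within the scatter), lay within the scatter. Compound 3 `CN1C[C@H](C(=O)Nc2cccnc2)[C@@H](c2ccc(/C=C/C(=O)Nc3ccccc3N)cc2)C1` differs from compound 2 in a single place: pyridin-3-yl in place of 2-fluorophenyl on an amide-type nitrogen. Going by the values given here, that earlier step also exchanged one group for another on the same amide-type nitrogen and moved nothing, so it bears on this change, though no measured compound carries a pyridin-3-yl. The account therefore expects a step of no change at the digits printed from compound 2 to compound 3 (within the scatter) of no size beyond the scatter. Compound 3 is estimated at 10 mL/min/kg, within a range of 5 mL/min/kg to 20 mL/min/kg.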

Compound 3, clearance: 10 mL/min/kg
For compound 3 middle estimate and measured number coincide at the digits printed, within the range that was stated.
By their numbers in this assay, from the lowest: compounds 1, 2 and 3 (each within the scatter of the next).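

In this assay, a ring with a hetero atom and a hydrogen-bond acceptor on the amide-type nitrogen gives no change at the digits printed from compound 2 to compound 3 (within the scatter) in this replacement of 2-fluorophenyl. Set against the 4-isopropylphenyl group, the same pyridin-3-yl gives no change at the digits printed from compound 1 to compound 3 (within the scatter), so the read-out does not separate these three aromatic groups at this place. Nothing given here accounts for this result.
From the compounds shown here alone, what remains open is whether a group without an aromatic ring on this nitrogen, such as cyclohexyl or a longer alkyl chain, would stay level as well. A chain ending in an amine or a carboxylic acid is likewise untested among the compounds shown.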